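Swapping a Benzimidazole Amine for a Methylpiperidine

This account rests on a few compounds, and the source may have more. Where it says the series, first, only, none or still open, it means among the compounds named here.

Of the compounds shown here, three built on one shared core have been measured in a physicochemical assay for lipophilicity; on this read-out higher numbers stand for higher lipophilicity and lower numbers for lower lipophilicity. Compound 1 `CC(C)Sc1nnc(-c2c(CN3CCCCC3C)c3ccccc3n2C)n1-c1ccccc1` gives 5.95 in this assay. Compound 2 `COCCNCc1c(-c2nnc(SC(C)C)n2-c2ccccc2)n(C)c2ccccc12` gives 4.36. Compound 3 `CC(C)Sc1nnc(-c2c(CNc3nc4ccccc4[nH]3)c3ccccc3n2C)n1-c1ccccc1` gives 5.94, the second highest of the three numbers; the step of a number 0.01 log units lower from compound 1 to compound 3 (within the scatter) keeps it within the scatter of its nearest neighbour, while the step of a number 1.58 log units higher from compound 2 to compound 3 (beyond the scatter) separates it clearly from the lowest compound.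

Compound 4 `CC1CCN(Cc2c(-c3nnc(SC(C)C)n3-c3ccccc3)n(C)c3ccccc23)CC1` has not yet been measured. Its structure differs from compound 3 in one place: 4-methylpiperidin-1-yl in place of (1H-benzimidazol-2-yl)amino on a saturated chain carbon bound to an aromatic carbon.

Among the compounds with values here, one measured step bears directly on this exchange. The step of a number 0.01 log units lower from compound 1 to compound 3 (within the scatter) replaced 2-methylpiperidin-1-yl with (1H-benzimidazol-2-yl)amino at the same place, and compound 4 carries 4-methylpiperidin-1-yl, a closely related group of the same size. Running that exchange backwards therefore suggests no change beyond the scatter. The two large steps, a number 1.59 log units lower from compound 1 to compound 2 (beyond the scatter) and a number 1.58 log units higher from compound 2 to compound 3 (beyond the scatter), both involve the (2-methoxyethyl)amino group, which is absent here, so they do not bear on this step.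

Compound 4 is therefore expected to show a step of a number 0.04 log units lower from compound 3 to compound 4 (within the scatter) relative to compound 3. The estimate for compound 4 in this assay is 5.9, with a likely range from 5.5 to 6.3.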

Compound 4, partition coefficient: 5.96
Beside the measured number, compound 4's estimate is 0.06 log units below it; measured number inside the range.
By their numbers in this assay, from the lowest: compound 2; then compounds 3, 1 and 4 (each within the scatter of the next).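

The step of a number 0.01 log units higher from compound 1 to compound 4 (within the scatter) shows that in this assay, moving the methyl from 2-methylpiperidin-1-yl to 4-methylpiperidin-1-yl leaves the number within the scatter, so this read-out does not separate these two arrangements of the piperidine. The step of a number 0.02 log units higher from compound 3 to compound 4 (within the scatter) extends this to a much less similar pair: (1H-benzimidazol-2-yl)amino has two aromatic rings, 10 heavy atoms and 2 hydrogen-bond donors, while 4-methylpiperidin-1-yl has one non-aromatic ring, 7 heavy atoms and no donors, yet the two compounds remain within the scatter of each other. The step of a number 1.60 log units higher from compound 2 to compound 4 (beyond the scatter) then confirms with a third ring-bearing group that, among the four compounds, those with a ring on this saturated chain carbon sit together, and compound 2, with its open (2-methoxyethyl)amino chain, is the one exception.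

Still open, on these data alone, is where the number would fall with a morpholine ring, a plain piperidine without the methyl, or a longer chain ending in a carboxylic acid at this place. Nothing available explains why these ring-bearing groups read alike or why compound 2 stands apart.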